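A few compounds are considered here, and "the series" means these few. Any claim that something is new, unique, unknown or untested is made for them only; others in the source may bear on it.

In a functional assay on CCRF-CEM cells (Homo sapiens) for antiproliferative activity (on this read-out lower numbers stand for higher toxicity in this test and higher numbers for lower toxicity in this test), three compounds sharing one core have been measured. Compound 1 (`Cc1cn(C2OC(CO[Si](C)(C)C(C)(C)C)C3(OS(=O)(=O)C=C3N)C2O[Si](C)(C)C(C)(C)C)c(=O)n(CCCNC(=O)[C@@H]2CCCN2C(=O)[C@@H](N)C(C)C)c1=O`) gives 10000 nM, compound 2 (`Cc1cn(C2OC(CO[Si](C)(C)C(C)(C)C)C3(OS(=O)(=O)C=C3N)C2O[Si](C)(C)C(C)(C)C)c(=O)n(CCCNC(=O)[C@@H]2CCCN2C(=O)[C@H](C)N)c1=O`) gives 19000 nM, and compound 3 (`Cc1cn(C2OC(CO[Si](C)(C)C(C)(C)C)C3(OS(=O)(=O)C=C3N)C2O[Si](C)(C)C(C)(C)C)c(=O)n(CCCNC(=O)[C@H](C)NC(=O)[C@@H](N)C(C)C)c1=O`) gives 11000 nM. Compound 3 therefore lies within the scatter of both others, and the three values cannot be put in an order. Compound 4 (`Cc1cn(C2OC(CO[Si](C)(C)C(C)(C)C)C3(OS(=O)(=O)C=C3N)C2O[Si](C)(C)C(C)(C)C)c(=O)n(CCCNC(=O)[C@H](CC(C)C)NC(=O)[C@@H](N)C(C)C)c1=O`) differs from compound 3 by a single change: isopropyl in place of hydrogen on a saturated chain carbon, two bonds along the chain from an amide-type nitrogen and a carbonyl carbon. Isopropyl takes the place of hydrogen on a saturated chain carbon, two bonds along the chain from an amide-type nitrogen and a carbonyl carbon; cut one bond further out, the same difference reads methyl to isobutyl. Within the data shown here, no measured pair shows this exact change. Among the measured compounds shown here, the closest precedent is a 1.9-fold higher number from compound 1 to compound 2 (0.28 log units; within the scatter), where methyl replaces isopropyl on a saturated chain carbon bound to an amine nitrogen and a carbonyl carbon. The larger replacements, a 1.1-fold higher number from compound 1 to compound 3 (0.04 log units; within the scatter) and a 1.7-fold lower number from compound 2 to compound 3 (0.24 log units; within the scatter), also left the values within the scatter. These steps give no reason to expect a shift beyond the scatter in this assay, and they suggest no direction. The expected step is a 1.1-fold lower number from compound 3 to compound 4 (0.04 log units; within the scatter), which is no real change. For compound 4 the estimated value is 10000 nM, with an expected range from 4500 nM to 22000 nM.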

Compound 4, half-maximal cytotoxic concentration: 11000 nM
Compound 4: middle estimate off by 1.1-fold (0.04 log units), on the low side; the range from low to high includes it.
By their numbers in this assay, from the lowest: compounds 1, 3, 4 and 2 (each within the scatter of the next).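

Among these compounds, the step at this place reads no change at the digits printed from compound 3 to compound 4 (within the scatter) in this assay, the first direct reading of isopropyl in place of hydrogen on a saturated chain carbon, two bonds along the chain from an amide-type nitrogen and a carbonyl carbon. The earlier steps shown here could only stand in for this change, since they concerned other replacements, whereas this one shows that a group of 3 carbon atoms with no ring, no hydrogen-bond donors and no hydrogen-bond acceptors can enter at this place with the number staying within the scatter. Nothing available explains this result.

Whether an amine, a carboxylic acid or a longer chain at this same carbon would carry the number beyond the scatter remains open, since isopropyl is the only group shown entering here. With each of the four compounds lying within the scatter of the next in this assay, the compounds shown also leave open whether any part of the side chain on the shared core matters for this read-out at all.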